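The compounds below may be only part of what the source reports. "The series", "measured", "known", "first", "only" and "open" are said of these compounds alone.

Compound 3 `COc1cc(/C=N/NC(=O)OCc2ccccc2)cc(O)c1O` gives 17% in a physicochemical assay on cells (Homo sapiens), with a stated time of 18 h, tested at 1 uM (a higher number here means a weaker effect of the compound at the concentration tested, a lower number a stronger effect), the lowest of the three numbers; compound 1 `COc1cc(/C=N/NC(=O)OCc2ccccc2)cc(OC)c1O` gives 38% and compound 2 `COc1cc(/C=N/NC(=O)OCc2ccccc2)cc(OC)c1OC` gives 95% in this assay. Compound 4 `O=C(N/N=C/c1ccc(O)c(O)c1)OCc1ccccc1` differs from compound 3 by hydrogen in place of methoxy on an aromatic carbon. Within the data shown here, no measured step matches this change; the two that bear on it are a number 57 percentage points higher from compound 1 to compound 2 (beyond the scatter) and a number 21 percentage points lower from compound 1 to compound 3 (beyond the scatter), both turning on whether a hydroxy or a methyl-bearing oxygen sits on the ring. Both hydroxy groups of compound 3 stay in compound 4, so the expectation is at most a modest step, a number 2 percentage points lower from compound 3 to compound 4 (within the scatter), in this assay. Compound 4 is therefore estimated at 15%, within 4% to 32%, to be checked against the measurement.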

Compound 4, a percentage reported as activity, at one concentration (the size of the read-out at that concentration, not a potency): 27%
For compound 4 the middle estimate is 12 percentage points below the measured one, and the stated range covers the measured number.
By their numbers in this assay, from the lowest: compounds 3 and 4 (each within the scatter of the next); then compound 1; then compound 2.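

Hydrogen in place of methoxy, on the aromatic carbon ortho to a hydroxy group, gives a number 10 percentage points higher from compound 3 to compound 4 (within the scatter) in this assay, so with both hydroxy groups kept the two substituents at this place cannot be told apart. The large differences seen so far, a number 57 percentage points higher from compound 1 to compound 2 (beyond the scatter) and a number 21 percentage points lower from compound 1 to compound 3 (beyond the scatter), came from changes on a ring oxygen, not from this carbon. No measurement on hand accounts for this result. On these data alone, whether an amine or a longer chain such as ethoxy at this carbon would read the same stays open. So does the effect of this change when a ring oxygen carries a methyl.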